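The source may hold more compounds than are shown below. What is called first, only, known or untested is meant among the compounds shown, and "the series" means these compounds.

In a functional assay on U-251 cells (Homo sapiens) for inhibition, read by sulforhodamine B assay, with a stated time of 48 h (on this read-out higher numbers stand for weaker inhibition of growth and lower numbers for stronger inhibition of growth), three compounds have been measured:
compound 1 `CC1=CC[C@H](C(C)(C)NC(=S)N/N=C/c2ccccc2)CC1` gives 26300 nM
compound 2 `CC1=CC[C@H](C(C)(C)NC(=S)N/N=C/c2ccccc2O)CC1` gives 6400 nM
compound 3 `CC1=CC[C@H](C(C)(C)NC(=S)N/N=C/c2cccc(Cl)c2)CC1` gives 7900 nM

Compound 3 stands second highest of these three numbers. Its nearest neighbour is compound 2, separated by a 1.2-fold higher number from compound 2 to compound 3 (0.09 log units; within the scatter); its furthest is compound 1, separated by a 3.3-fold lower number from compound 1 to compound 3 (0.52 log units; beyond the scatter). Compound 4 `CC1=CC[C@H](C(C)(C)NC(=S)N/N=C/c2cccc([N+](=O)[O-])c2)CC1` differs from compound 3 by nitro in place of chloro on an aromatic carbon. Among the compounds with values here, two measured steps bear on this change: both substitutions of the unsubstituted ring, a 4.1-fold lower number from compound 1 to compound 2 (0.61 log units; beyond the scatter) and a 3.3-fold lower number from compound 1 to compound 3 (0.52 log units; beyond the scatter), lowered the number modestly, while exchanging one substituted ring for another, a 1.2-fold higher number from compound 2 to compound 3 (0.09 log units; within the scatter), stayed within the scatter. Swapping one ring substituent for another is therefore expected to give no step beyond the scatter in this assay. Compound 4 is estimated at 7000 nM, with a range from 3000 nM to 18000 nM, an expected step of a 1.1-fold lower number from compound 3 to compound 4 (0.05 log units; within the scatter).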

Compound 4, concentration for 50% growth inhibition: > 100000 nM
Compound 4: no number, only a limit; the forecaster's own chance of this, stated with the estimate: 5%; at least 14-fold (1.15 log units) between middle value and limit.
By their numbers in this assay, from the lowest: compounds 2 and 3 (each within the scatter of the next); then compound 1. At a limit, above all of these: compound 4.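

Compound 4 has no number in this assay, only a limit: the limit of > 100000 nM in this assay, at which 1 of the 4 values shown sits. Nitro in place of chloro gives an at least 12-fold higher number from compound 3 to compound 4 (1.10 log units; beyond the scatter), and nitro in place of hydrogen gives an at least 3.8-fold higher number from compound 1 to compound 4 (0.58 log units; beyond the scatter), whereas chloro in place of hydrogen gave a 3.3-fold lower number from compound 1 to compound 3 (0.52 log units; beyond the scatter). On this aromatic carbon, meta to a large group, the direction of the step therefore depends on the group that enters, and exchanging one substituent for another can produce a large step.

The compounds shown leave open how an amine, a nitrile or a methoxy group on this carbon would read, and so whether nitro stands alone in raising the number.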